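The source may hold more compounds than are shown below. What is called first, only, known or untested is meant among the compounds shown, and "the series" means these compounds.

Measured compounds:
- compound 1, `Cc1ncc([N+](=O)[O-])n1CCSc1nnc(-c2ccccc2)o1`, 30100 nM
- compound 2, `Cc1ccc(-c2nnc(SCCn3c([N+](=O)[O-])cnc3C)o2)cc1`, 12500 nM
- compound 3, `Cc1ncc([N+](=O)[O-])n1CCSc1nnc(-c2ccccc2O)o1`, 30500 nM

All three were tested in a functional assay on SGC-7901 cells (Homo sapiens) for cytotoxicity, read by MTT assay, with a stated time of 48 h; on this read-out lower numbers stand for stronger inhibition and higher numbers for weaker inhibition. Compound 1 stands at 30100 nM, and compound 2 at 12500 nM. The change that separates them is methyl in place of hydrogen on an aromatic carbon, and it produced a 2.4-fold lower number from compound 1 to compound 2 (0.38 log units; beyond the scatter). Compound 3 carries a different core: the difference from compound 1 is hydroxy in place of hydrogen on an aromatic carbon, and it gave a 1.0-fold higher number from compound 1 to compound 3 (0.01 log units; within the scatter). Between compound 2 and compound 3 the data show a 2.4-fold higher number from compound 2 to compound 3 (0.39 log units; beyond the scatter).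

Compound 4, `Cc1cccc(-c2nnc(SCCn3c([N+](=O)[O-])cnc3C)o2)c1O`, has not yet been measured in this assay. Its difference from compound 3 is methyl in place of hydrogen on an aromatic carbon. Among the measured compounds shown here, this is the same kind of change as the one from compound 1 to compound 2, but not the same: in the earlier pair the methyl sits para to a large group, whereas in compound 4 it sits ortho to a hydroxy group and meta to a large group, on the core that already carries the hydroxy of compound 3.

Because a 2.4-fold lower number from compound 1 to compound 2 (0.38 log units; beyond the scatter), a lowering of the number is expected here too, though the changed surroundings leave room for a smaller step. The expected step is a 1.8-fold lower number from compound 3 to compound 4 (0.25 log units; within the scatter). Compound 4 is therefore estimated at 17000 nM, with a range from 8000 nM to 38000 nM.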

Compound 4, half-maximal inhibitory concentration: 35900 nM
Estimate against measurement, compound 4: 2.1-fold (0.32 log units) below, and the stated range covers the measured number.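

In this assay, the methyl step did not carry over from one core to the other: the same change on two cores in this assay, a 2.4-fold lower number (0.38 log units; beyond the scatter) from compound 1 to compound 2 and a 1.2-fold higher number (0.07 log units; within the scatter) from compound 3 to compound 4, 2.8-fold (0.45 log units) apart, beyond the scatter of two such steps

On the core of compound 3, the new step is a 1.2-fold higher number from compound 3 to compound 4 (0.07 log units; within the scatter). The wider comparisons read a 1.2-fold higher number from compound 1 to compound 4 (0.08 log units; within the scatter) and a 2.9-fold higher number from compound 2 to compound 4 (0.46 log units; beyond the scatter), so compound 2 is the only one of the four set apart, and it has the lowest number of the series. This does not show what lies behind the difference, since the two pairs differ both in the hydroxy group on the ring and in where the methyl sits, and a single pair for each case cannot separate those two things or show how either would behave on further cores.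

The compounds shown leave open whether the 4-methylphenyl result would return with a hydroxy group elsewhere on the ring, or with a methoxy group in place of that hydroxy. They also leave open whether an ethyl group, a chlorine atom or an amine in place of the methyl would follow compound 2 or compound 4 on either core.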